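This account rests on a few compounds, and the source may have more. Where it says the series, first, only, none or still open, it means among the compounds named here.

Compound 1, `CCn1c(C(=O)N[C@@H](C)C(=O)OC)ccc1C(CC)(CC)c1ccc(OCS(=O)(=O)c2ccccc2)c(C)c1`: 43700 nM
Compound 2, `CCn1c(C(=O)N[C@H](C)C(=O)OC)ccc1C(CC)(CC)c1ccc(OCS(=O)(=O)c2ccccc2)c(C)c1`: a limit only, > 50000 nM
Compound 3, `CCn1c(C(=O)NCCO)ccc1C(CC)(CC)c1ccc(OCS(=O)(=O)c2ccccc2)c(C)c1`: 15500 nM

In a functional assay on MCF7 cells (Homo sapiens) for antiproliferative activity, read by MTT assay, with a stated time of 24 h (a lower number here means a stronger inhibitor, a higher number a weaker inhibitor), compound 1 gives 43700 nM. Compound 2 does not reach a number at all; its result is the limit of the measurement, > 50000 nM, so only its lowest possible value is known (the limit of > 50000 nM in this assay, at which 1 of the 3 values shown sits). Compound 3 gives 15500 nM. The step of an at least 1.1-fold higher number from compound 1 to compound 2 (0.05 log units; that floor lies within the scatter) rests on two compounds that share all their atoms and bonds (the fact that compounds 1 and 2 differ only in the configuration as drawn). The steps of a 2.8-fold lower number from compound 1 to compound 3 (0.45 log units; beyond the scatter) and an at least 3.2-fold lower number from compound 2 to compound 3 (0.50 log units; beyond the scatter) both swap the whole 1-(methoxycarbonyl)ethyl group for 2-hydroxyethyl, so neither tests the change of interest here exactly.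

Compound 4, `CCn1c(C(=O)N[C@H](C)C(=O)O)ccc1C(CC)(CC)c1ccc(OCS(=O)(=O)c2ccccc2)c(C)c1`, differs from compound 2 only by hydrogen in place of methyl on an oxygen next to a carbonyl group. Within the data shown here, no measured step covers this change by itself; the nearest comparisons, the two steps that remove the methoxycarbonyl part entirely, moved the number only modestly. Compound 2 itself sits at a limit, so there is room for the number to stay beyond the measurable range. Compound 4 is therefore expected to give about 45000 nM, with a plausible range from 15000 nM to 120000 nM, and the expected step is an at least 1.1-fold lower number from compound 2 to compound 4 (0.04 log units; that floor lies within the scatter).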

Compound 4, half-maximal inhibitory concentration: > 50000 nM
Compound 4 was reported as a limit; the forecaster's own chance of this, stated with the estimate: 55%; at least 1.1-fold (0.04 log units) between middle value and limit.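

In this assay compound 4 gives only a limit, > 50000 nM, not a number. Compound 2 sits at the same limit, so the effect of hydrogen in place of methyl on this oxygen cannot be read from the two compounds: the limit of > 50000 nM in this assay, at which 2 of the 4 values shown sit. What the result does add is that the 1-carboxyethyl group on the amide-type nitrogen, like the 1-(methoxycarbonyl)ethyl group, does not match the 2-hydroxyethyl group, with an at least 3.2-fold higher number from compound 3 to compound 4 (0.50 log units; beyond the scatter), while an at least 1.1-fold higher number from compound 1 to compound 4 (0.05 log units; that floor lies within the scatter) gives no order between those two compounds.

On these data alone, both compounds at the limit could still differ from each other at concentrations beyond the limit, and it remains open whether the 1-carboxyethyl group drawn with the opposite configuration, as in the ester compound 1, would give a readable number. Also open, as far as these compounds go, is how this amide-type nitrogen would respond to a 3-hydroxypropyl chain or a 2-aminoethyl group in place of 2-hydroxyethyl, which would show whether compound 3 can be improved on from this position.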